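Urea to amide: a step without a measured precedent

The source may hold more compounds than are shown below. What is called first, only, known or untested is meant among the compounds shown, and "the series" means these compounds.

Compound 2 `COc1cc(Cl)cc(-c2nn(-c3cccc(NC(=O)Nc4ccc(Cl)c(Cl)c4)c3)cc2-c2ccncc2)c1` stands highest of the two numbers in a functional assay on HCT-15 cells (Homo sapiens) for inhibition, read by sulforhodamine B assay, with a stated time of 48 h, tested at 1 uM; on this read-out lower numbers stand for a stronger effect and higher numbers for a weaker effect at the one concentration tested; its nearest neighbour is compound 1 `O=C(Nc1cccc(-n2cc(-c3ccncc3)c(-c3cc(O)cc(Cl)c3)n2)c1)Nc1ccc(Cl)c(Cl)c1`, and in this assay compound 1 gives 75% while compound 2 gives 77%. Among the compounds with values here, the one measured step, a number 2 percentage points higher from compound 1 to compound 2 (within the scatter), lies within the scatter and concerns an oxygen substituent far from the carbonyl, so it does not bear on what follows.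

Compound 3 `COc1cc(Cl)cc(-c2nn(-c3cccc(NC(=O)c4cccc(C(F)(F)F)c4)c3)cc2-c2ccncc2)c1` differs from compound 2 at the carbonyl: 3-(trifluoromethyl)phenyl in place of (3,4-dichlorophenyl)amino on a carbonyl carbon. Within the data shown here, no measured step touches this part of the molecule, so the data give no guide to the direction or size of the change.

Compound 3 is therefore expected to land near compound 2, at about 80%, with a wide range from 58% to 100%; the step of a number 3 percentage points higher from compound 2 to compound 3 (within the scatter) is an estimate with no precedent beyond the scatter.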

Compound 3, a percentage reported as activity, at one concentration (the size of the read-out at that concentration, not a potency): 71%
Compound 3: middle estimate off by 9 percentage points, on the high side, within the range that was stated.
By their numbers in this assay, from the lowest: compounds 3, 1 and 2 (each within the scatter of the next).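

In this assay the carbonyl carbon takes 3-(trifluoromethyl)phenyl in place of (3,4-dichlorophenyl)amino with a number 6 percentage points lower from compound 2 to compound 3 (within the scatter), so this first change at the position, which turns the urea into an amide, gives no readable shift at the one concentration tested. The exchange removes the hydrogen-bond donor of the leaving group and swaps two chlorines for a trifluoromethyl group, yet the read-out does not separate compound 3 from compound 2. No measurement shown here explains this outcome.

Because several features change in this single exchange, the compounds shown cannot say which of them, if any, matters on its own. Going by these compounds, whether a different group on the carbonyl carbon, such as a morpholine or a longer alkyl chain, would move the number beyond the scatter remains open.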